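Swapping a pyrrole for a furan on a cyanoacrylamide

The source may report more compounds than this note shows. Statements on the series, on what has been measured and on what is new or still open speak of the compounds shown alone.

Measured compounds:
Compound 1 `N#C/C(=C\c1ccc(Cl)cc1)C(=O)c1ccc[nH]1` gives 27000 nM in a functional assay on MCF7 cells (Homo sapiens) for inhibition, read by MTT assay, with a stated time of 72 h; a lower number here means a stronger inhibitor of growth, a higher number a weaker inhibitor of growth.
Compound 2 `N#C/C(=C\c1c(F)c(F)c(F)c(F)c1F)C(=O)c1c[nH]c2ccccc12` gives 13000 nM in this assay.
Compound 3 `COc1ccc(CNC(=O)/C(C#N)=C/c2ccc[nH]2)cc1` gives 34000 nM in this assay.

Compound 3 shows the highest number of the three. Compared with compound 1, the two values lie within the usual scatter of this kind of measurement, so they cannot be told apart. Compound 2, by contrast, sits lower by a gap that lies beyond the scatter.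

Compound 4 `COc1ccc(CNC(=O)/C(C#N)=C/c2ccco2)cc1` has not yet been measured. It differs from compound 3 in one place: furan-2-yl in place of 1H-pyrrol-2-yl on a double-bonded chain carbon bound to a double-bonded chain carbon. Within the data shown here, no measured pair in this set shows the effect of such a swap, so there is no step to lean on. Since the two rings are of the same size and differ only in the single hetero atom and its hydrogen-bond pattern, the expectation is a step from compound 3 to compound 4 of a 1.0-fold higher number from compound 3 to compound 4 (0.01 log units; within the scatter) in this assay, that is, none beyond the scatter. Compound 4 is accordingly estimated at 35000 nM, within a range of 12000 nM to 100000 nM.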

Compound 4, concentration for 50% growth inhibition: 27000 nM
For compound 4 the middle estimate is 1.3-fold (0.11 log units) above the measured one; low and high end bracket the measured number.
By their numbers in this assay, from the lowest: compound 2; then compounds 1, 4 and 3 (each within the scatter of the next).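

At this place, on a double-bonded chain carbon bound to a double-bonded chain carbon, the ring swap gives a 1.3-fold lower number from compound 3 to compound 4 (0.10 log units; within the scatter) in this assay and so cannot be told apart from no change. Exchanging 1H-pyrrol-2-yl, with its hydrogen-bond donor, for furan-2-yl, with a hydrogen-bond acceptor and no donor, therefore leaves growth inhibition in this pair unchanged within the scatter, which means the ring's donor is not needed to hold this level of activity. Nothing measured here explains why the two rings read alike.

Still open, as far as these compounds go, is whether a five-membered aromatic ring with sulfur as its hetero atom, or an amine on the ring, would read the same at this place. A single pair also cannot show whether the swap behaves alike on other cores.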